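Taking the nitro group off compound 3

The source may hold more compounds than are shown below. What is called first, only, known or untested is meant among the compounds shown, and "the series" means these compounds.

In a functional assay on A549 cells (Homo sapiens) for antiproliferative activity, read by MTT assay, with a stated time of 72 h (a lower number here means a stronger inhibitor, a higher number a weaker inhibitor), compound 3 `O=[N+]([O-])c1ccc(COc2cccc(Nc3ncnc4cc5c(cc34)OCCOCCO5)c2)cc1` gives a half-maximal inhibitory concentration of 15500 nM and compound 1 `FC(F)(F)c1ccc(COc2ccc(Nc3ncnc4cc5c(cc34)OCCOCCOCCO5)cc2)cc1` gives 30700 nM as its value, so these two lie within the scatter of each other. Compound 2 `FC(F)(F)c1ccc(COc2cccc(Nc3ncnc4cc5c(cc34)OCCOCCO5)c2)cc1` reads > 100000 nM as its result, which is a limit of the assay and not a number.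

Compound 4 `c1ccc(COc2cccc(Nc3ncnc4cc5c(cc34)OCCOCCO5)c2)cc1` changes compound 3 in one place: hydrogen in place of nitro on an aromatic carbon puts hydrogen in place of nitro, para to a large group. For the measured compounds named here, one measured step bears on this site: nitro in place of trifluoromethyl gave an at least 6.4-fold lower number from compound 2 to compound 3 (0.80 log units; beyond the scatter) as its change, beyond the scatter. That step shows compound 3 holding the lower number, but hydrogen itself has not been tested here. A rise is therefore expected, probably smaller than that step. The estimated change is a 2.6-fold higher number from compound 3 to compound 4 (0.41 log units; beyond the scatter) in this assay as a rough guide. For compound 4 the estimated value is 40000 nM with an expected range from 13000 nM to 100000 nM as its likely span.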

Compound 4, half-maximal inhibitory concentration: 7590 nM
Beside the measured number, compound 4's estimate is 5.3-fold (0.72 log units) above it, and the stated range ends above it.
By their numbers in this assay, from the lowest: compound 4; then compounds 3 and 1 (each within the scatter of the next). At a limit, above all of these: compound 2.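

In this assay, the nitro group proves unnecessary at this position on the aromatic ring: replacing it with hydrogen gives a 2.0-fold lower number from compound 3 to compound 4 (0.31 log units; beyond the scatter). The earlier pair showed only that nitro gave a lower number than trifluoromethyl, whereas the ring with neither group now gives an at least 13-fold lower number from compound 2 to compound 4 (1.11 log units; beyond the scatter), so among these three close relatives, both groups give higher numbers than plain hydrogen. That second step starts from compound 2, whose value is a limit and not a number, so its size is only a bound: the limit of > 100000 nM in this assay, at which 1 of the 4 values shown sits.

The compounds shown leave open how an amine or a carboxylic acid at this place would compare with hydrogen. They also leave open whether the same order of groups would hold on the core of compound 1.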